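Replacing the Butoxymethyl Chain on a Quinazoline Piperidine Ether

A few compounds are considered here, and "the series" means these few. Any claim that something is new, unique, unknown or untested is made for them only; others in the source may bear on it.

Measured compounds:
Compound 1, `CCCCOCCOC1CCN(c2nc(N)c3cc(OC)c(OC)cc3n2)CC1`: 1.03 nM
Compound 2, `CCOC(COC1CCN(c2nc(N)c3cc(OC)c(OC)cc3n2)CC1)c1ccccc1`: 0.52 nM

Both compounds were tested in an assay on brain for displacement of a labelled ligand from Adrenergic receptor alpha-1 (Rattus norvegicus); a lower number here means a stronger inhibitor, a higher number a weaker inhibitor. Compound 1, with 1.03 nM, has the highest of the two numbers; its nearest neighbour is compound 2, and the step of a 2.0-fold lower number from compound 1 to compound 2 (0.30 log units; within the scatter) does not rise beyond the scatter, so the two cannot be ordered against each other.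

The new compound is compound 3, `COc1cc2nc(N3CCC(OCC(O)c4ccccc4)CC3)nc(N)c2cc1OC`. It differs from compound 1 as follows: hydroxy(phenyl)methyl in place of butoxymethyl on a saturated chain carbon bound to an oxygen on a saturated carbon. Among the measured compounds shown here, the only measured step that bears on this change is the one from compound 1 to compound 2, in which an ethoxy(phenyl)methyl group took the place of the same butoxymethyl group; that step, a 2.0-fold lower number from compound 1 to compound 2 (0.30 log units; within the scatter), stayed within the scatter. For the measured compounds named here, compound 3 carries the same phenyl-bearing fragment, but with a hydroxyl in place of the ethoxy, a change for which no step is available. The expectation for compound 3 is therefore a step of a 1.4-fold lower number from compound 1 to compound 3 (0.14 log units; within the scatter), that is, no change beyond the scatter. Compound 3 is estimated to give 0.75 nM, within a range from 0.25 nM to 2.5 nM.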

Compound 3, inhibition constant: 0.15 nM
Beside the measured number, compound 3's estimate is 5.0-fold (0.70 log units) above it; measured number below the stated range.
By their numbers in this assay, from the lowest: compound 3; then compounds 2 and 1 (each within the scatter of the next).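

In this assay, the hydroxy(phenyl)methyl group in place of butoxymethyl gives a 6.9-fold lower number from compound 1 to compound 3 (0.84 log units; beyond the scatter), a step beyond the scatter at a place where the ethoxy(phenyl)methyl group had given only a 2.0-fold lower number from compound 1 to compound 2 (0.30 log units; within the scatter). The phenyl-bearing fragment alone therefore does not account for the result: compound 2 and compound 3 both carry it, yet hydrogen in place of ethyl on the oxygen gives a 3.5-fold lower number from compound 2 to compound 3 (0.54 log units; beyond the scatter), which is also beyond the scatter and leaves compound 3 with the lowest number of the three. At this position, then, what sits on that oxygen changes the number, although nothing available here explains why the free hydroxyl goes with the lower value.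

On these data alone, it remains open whether an amine or a methoxy group in place of that hydroxyl would keep the number as low as in compound 3. As far as these compounds go, it is equally open whether the phenyl ring is needed at all, which a plain 2-hydroxyethyl chain or a 2-hydroxypropyl chain at the same place could show.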